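The compounds below may be only part of what the source reports. "The series", "measured", "known", "first", "only" and "open" are said of these compounds alone.

Measured compounds:
compound 1 `O=C(CCCCCn1cc(Nc2ncc3ccn(Cc4ccc(F)cc4)c3n2)cn1)NO`: 46%
compound 2 `O=C(CCCCCCn1cc(Nc2ncc3ccn(Cc4ccc(F)cc4)c3n2)cn1)NO`: 62%

In an assay on isolated protein for inhibition of protein deacetylase HDAC6 (Homo sapiens), with a stated time of 60 min, tested at 10 nM (on this read-out higher numbers stand for more inhibition at the one concentration tested (going by the name of the read-out) and lower numbers for less inhibition), compound 1 stands lowest of the two numbers; the step of a number 16 percentage points higher from compound 1 to compound 2 (beyond the scatter) separates it from compound 2. Compound 3 `O=C(CCCCCn1cc(Nc2ncc3ccn(Cc4ccc(Cl)cc4)c3n2)cn1)NO` differs from compound 1 by chloro in place of fluoro on an aromatic carbon. No measured step touches the halogen on the benzyl ring: the single step shown concerns the chain length alone, so it offers no direct guide to this change. Compound 3 is therefore expected to sit close to compound 1, with the step of a number 4 percentage points higher from compound 1 to compound 3 (within the scatter) not clearly beyond the scatter. Compound 3 is estimated at 50%, within a range from 30% to 70%.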

Compound 3, a percentage reported as inhibition, at one concentration (the size of the read-out at that concentration, not a potency): 38%
Estimate against measurement, compound 3: 12 percentage points above; the range from low to high includes it.
By their numbers in this assay, from the lowest: compounds 3 and 1 (each within the scatter of the next); then compound 2.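

Within this assay, the change from 4-fluorobenzyl to 4-chlorobenzyl gives a number 8 percentage points lower from compound 1 to compound 3 (within the scatter), so this read-out does not separate the two halogens at this place on the ring. Going by these compounds alone, this is the first view of the compounds away from the chain, where the step was a number 16 percentage points higher from compound 1 to compound 2 (beyond the scatter). Nothing available explains the result.

Open, from the compounds shown here alone, is whether an unsubstituted benzyl, a methoxy or a trifluoromethyl group at this place would move the number beyond the scatter. Also open, going by these compounds, is whether chloro and fluoro would stay equally close on the longer chain of compound 2.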